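Swapping an arylamino group for phenyl on a carbonyl

The source may report more compounds than this note shows. Statements on the series, on what has been measured and on what is new or still open speak of the compounds shown alone.

Measured so far in a functional assay on MDA-MB-435 cells (Homo sapiens) for inhibition, read by sulforhodamine B assay, with a stated time of 48 h; a higher number here means a weaker inhibitor, a lower number a stronger inhibitor
- compound 1 (`COc1cc(-c2nn(-c3cccc(NC(=O)Nc4ccc(Cl)c(Cl)c4)c3)cc2-c2ccncc2)ccc1Cl`) gives 940 nM
- compound 2 (`COc1cc(-c2nn(-c3cccc(NC(=O)Nc4cccc(C(F)(F)F)c4)c3)cc2-c2ccncc2)ccc1Cl`) gives 870 nM

In this assay compound 2 gives 870 nM and cannot be told apart from compound 1, so the two stand together on the numbers available. Compound 3 (`COc1cc(-c2nn(-c3cccc(NC(=O)c4ccccc4)c3)cc2-c2ccncc2)ccc1Cl`) carries phenyl in place of (3-(trifluoromethyl)phenyl)amino on a carbonyl carbon. For the measured compounds named here, only one measured step exists to compare it with: a 1.1-fold lower number from compound 1 to compound 2 (0.03 log units; within the scatter). That step exchanged 3,4-dichlorophenyl for 3-(trifluoromethyl)phenyl on an amide-type nitrogen, and it kept the nitrogen itself. Going by the values given here, compound 3 loses that amino nitrogen along with the substituted ring, and no measured compound shows what such a loss does. The small size of the measured step therefore offers only weak guidance here. A change this much larger than the one already tested could well move the number, and a modest shift towards a weaker inhibitor is expected, with wide uncertainty. The estimated step is a 2.3-fold higher number from compound 2 to compound 3 (0.36 log units; beyond the scatter) (an expectation, not a measurement). Compound 3 is expected at about 2000 nM (estimated range 700 nM to 6000 nM).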

Compound 3, half-maximal inhibitory concentration: 190 nM
The estimate for compound 3 lay 11-fold (1.02 log units) above the measured number; the measured number lies below the stated range.
By their numbers in this assay, from the lowest: compound 3; then compounds 2 and 1 (each within the scatter of the next).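

In this assay, putting phenyl in place of (3-(trifluoromethyl)phenyl)amino on the carbonyl carbon gives a 4.6-fold lower number from compound 2 to compound 3 (0.66 log units; beyond the scatter), and putting phenyl in place of (3,4-dichlorophenyl)amino there gives a 4.9-fold lower number from compound 1 to compound 3 (0.69 log units; beyond the scatter). Exchanging one substituted ring for the other while keeping the amino nitrogen had left the number within the scatter, whereas this position does respond when the nitrogen and the substituted ring leave together, and an amino nitrogen on this carbonyl carbon is clearly not required for compound 3 to reach the lowest number of the three. No evidence is available to explain this drop in the number.

The nitrogen and the ring substituents changed in a single move, so the compounds shown cannot separate the contribution of each; an unsubstituted phenylamino group on the carbonyl carbon, or a 3-(trifluoromethyl)phenyl group attached directly to it, would pull the two apart. As far as these compounds go, whether an aromatic ring is needed at this position at all also remains open, and a cyclohexyl or methyl group on the carbonyl carbon would address that question.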